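Isobutoxy in Place of 2,4-Dichlorophenyl on the Carbonyl

The source may report more compounds than this note shows. Statements on the series, on what has been measured and on what is new or still open speak of the compounds shown alone.

Compound 1 `Cc1ccccc1C(=O)Nc1ccc2nc(NC(=O)C3CCCCC3)sc2c1`: in a functional assay on WI-38 VA13 cells (Homo sapiens) for cytotoxicity (on this read-out lower numbers stand for an effect already at smaller amounts and higher numbers for an effect only at larger amounts of compound), compound 1 gives 0.085 ug/mL.
Compound 2 `O=C(Nc1ccc2nc(NC(=O)C3CCCCC3)sc2c1)c1ccc(Cl)cc1Cl`: compound 2 reaches only a limit of the assay, > 4 ug/mL.

Compound 2 thus stands at the limit of > 4 ug/mL in this assay, at which 1 of the 2 values shown sits, with no number of its own. Within the data shown here, the one measured step, an at least 47-fold higher number from compound 1 to compound 2 (1.67 log units; beyond the scatter), concerns the aryl group and says nothing about an alkoxy group. Compound 3 `CC(C)COC(=O)Nc1ccc2nc(NC(=O)C3CCCCC3)sc2c1` differs from compound 2 by isobutoxy in place of 2,4-dichlorophenyl on a carbonyl carbon. With compound 2 at a limit, the size of the step in this assay cannot be judged from the data; the direction is open. Compound 3 is estimated at 1.5 ug/mL, between 0.2 ug/mL and 4 ug/mL. This estimate means an at least 2.6-fold lower number from compound 2 to compound 3 (0.42 log units; beyond the scatter) is expected.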

Compound 3, half-maximal effective concentration: 0.72 ug/mL
Compound 3: middle estimate off by 2.1-fold (0.32 log units), on the high side, and the stated range covers the measured number.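

In this assay, replacing 2,4-dichlorophenyl with isobutoxy on the carbonyl carbon brings an at least 5.5-fold lower number from compound 2 to compound 3 (0.74 log units; beyond the scatter), so this position can carry a group with no ring and still give a measured number. Compound 2 stands only at a limit, so that step is a bound and not an exact size: the limit of > 4 ug/mL in this assay, at which 1 of the 3 values shown sits. The ring-free group does not match the 2-methylphenyl group, however, as isobutoxy in place of it gives an 8.5-fold higher number from compound 1 to compound 3 (0.93 log units; beyond the scatter). On these data alone, how an amine or a longer alkoxy chain would read on this carbonyl carbon stays open.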